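Swapping methoxy for fluoro on the aromatic ring of compound 2

The compounds below may be only part of what the source reports. "The series", "measured", "known", "first", "only" and "open" are said of these compounds alone.

Measured compounds:
compound 1, `CCC(=O)N(c1cccc(C)c1)C1CCCC1N(C)C`: 25 mg/kg; 25 mg/kg (2 entries)
compound 2, `CCC(=O)N(c1cccc(OC)c1)C1CCCC1N(C)C`: 4 mg/kg

In a functional assay on the whole organism for positive allosteric modulation, with Mus musculus as the target (a higher number here means that more compound is needed for the effect, a lower number that less compound is needed), compound 1 gives 25 mg/kg; 25 mg/kg (2 entries). Compound 2, `CCC(=O)N(c1cccc(OC)c1)C1CCCC1N(C)C`, gives 4 mg/kg in this assay, the lower of the two values shown. Compound 3, `CCC(=O)N(c1cccc(F)c1)C1CCCC1N(C)C`, differs from compound 2 by fluoro in place of methoxy on an aromatic carbon. Within the data shown here, no measured pair shows this change, so the expected step of a 2.5-fold higher number from compound 2 to compound 3 (0.40 log units; beyond the scatter) is a moderate one toward more compound needed, possibly just beyond the scatter. Compound 3 is therefore estimated at 10 mg/kg, with a range from 3 mg/kg to 35 mg/kg.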

Compound 3, dose for half-maximal effect: 5 mg/kg
Beside the measured number, compound 3's estimate is 2.0-fold (0.30 log units) above it; the measured number falls inside the stated range.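

In this assay, the swap gives a 1.3-fold higher number from compound 2 to compound 3 (0.10 log units; within the scatter), so at this place, meta to a large group, fluoro can stand in for methoxy with no readable change in dose. The hydrogen-bond acceptor counted for methoxy is therefore not required to reach a dose at this level. No measurement shown offers a reason for this result. As far as these compounds go, it remains open whether a larger group at this place, such as trifluoromethyl, or an amine would keep the dose within the scatter. The compounds shown also leave open how the unsubstituted ring would compare.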